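Extending the amide chain on a dihydrobenzoxazole cyclopropane series

This account rests on a few compounds, and the source may have more. Where it says the series, first, only, none or still open, it means among the compounds named here.

The series here rests on two measured compounds. Compound 1 `CCC1Nc2cccc([C@@H]3C[C@H]3CNC(C)=O)c2O1` gives 0.35 nM in an assay on NIH3T3 cells with melatonin receptor type 1A (Homo sapiens) as the target (a higher number here means a weaker inhibitor, a lower number a stronger inhibitor), which is the higher of the two numbers recorded. Compound 2 `CCCC(=O)NC[C@@H]1C[C@H]1c1cccc2nc(CC)oc12` gives 0.05 nM in this assay; it differs from compound 1 in more than one place, so the two values can only be set side by side without tracing the gap to a single change.

Compound 3 `CCC1Nc2cccc([C@@H]3C[C@H]3CNC(=O)C(C)C)c2O1` is built from compound 1 by one change: isopropyl in place of methyl on a carbonyl carbon. Among the compounds with values here, no measured pair shows this exact step. Given that compound 2 carries a longer acyl group and gives 0.05 nM, a modest move toward a lower number is expected, though a result within the usual scatter would not surprise. Compound 3 is expected to give 0.25 nM in this assay, between 0.08 nM and 0.8 nM. This expected step from compound 1 to compound 3 amounts to a 1.4-fold lower number from compound 1 to compound 3 (0.15 log units; within the scatter).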

Compound 3, inhibition constant: 0.2 nM
For compound 3 the middle estimate is 1.3-fold (0.10 log units) above the measured one, within the range that was stated.
By their numbers in this assay, from the lowest: compound 2; then compounds 3 and 1 (each within the scatter of the next).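

Isopropyl in place of methyl on a carbonyl carbon, whose other neighbour is the amide-type nitrogen, gives a 1.8-fold lower number from compound 1 to compound 3 (0.24 log units; within the scatter) in this assay. Within the data shown here, this is the first step that can be read at a single place, and it shows that this position holds isopropyl as well as methyl with no change beyond the scatter. Nothing at hand bears on why the step is this small.

Compound 2 differs from compound 3 in more than one place, so its lower number cannot be traced to the group on the carbonyl carbon. From the compounds shown here alone, it remains open how a straight propyl chain, a cyclopropyl ring or a phenyl ring would behave at this position on the core of compound 1, and whether a larger group would move the number beyond the scatter.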